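The source may hold more compounds than are shown below. What is called first, only, known or untested is meant among the compounds shown, and "the series" means these compounds.

Measured compounds in a functional assay on A549 cells (Homo sapiens) for cytotoxicity, read by MTT assay, with a stated time of 48 h; a lower number here means a stronger inhibitor, a higher number a weaker inhibitor:

Compound 1 `Cc1ccc(OCc2cn(-c3ccc(S(=O)(=O)N4CCc5ccccc5C4)cc3)nn2)cc1` gives > 50 ug/mL, which is a limit of the assay and not a number.
Compound 2 `O=S(=O)(c1ccc(-n2cc(COc3ccccc3)nn2)cc1)N1CCc2ccccc2C1` gives > 50 ug/mL, again only a limit.
Compound 3 `O=S(=O)(c1ccc(-n2cc(COc3ccc4ccccc4c3)nn2)cc1)N1CCc2ccccc2C1` gives > 50 ug/mL, also a limit.

Compound 3 therefore stands at the limit shared by every value shown (the limit of > 50 ug/mL in this assay, at which 3 of the 3 values shown sit); no number separates it from compound 1 or compound 2. The three measured steps, a step that the two limits leave unreadable from compound 1 to compound 2, a step that the two limits leave unreadable from compound 1 to compound 3 and a step that the two limits leave unreadable from compound 2 to compound 3, have no readable size; both ends of each sit at that limit.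

Compound 4 `O=S(=O)(c1ccc(-n2cc(CO)nn2)cc1)N1CCc2ccccc2C1` differs from compound 3 by hydrogen in place of naphthalen-2-yl on an oxygen on a saturated carbon. Among the measured compounds shown here, none of the measured steps removes the whole aryloxy group, and none has a readable size, so the expected step that the limit leaves unreadable from compound 3 to compound 4 rests on the unbroken run of limits alone. Compound 4 is expected near 80 ug/mL, within 40 ug/mL to 200 ug/mL, and most likely to be reported again only as a limit.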

Compound 4, half-maximal inhibitory concentration: > 50 ug/mL
Compound 4 gave a limit, no number (the forecaster's own chance of this, stated with the estimate: 85%); the middle value lies beyond the limit too.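

In this assay compound 4 gives > 50 ug/mL, a limit and not a number. Its steps from compound 1, compound 2 and compound 3 cannot be read. The compounds shown leave open whether the group on the oxygen changes the read-out at all, with every value at one shared limit: the limit of > 50 ug/mL in this assay, at which 4 of the 4 values shown sit.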